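The source may hold more compounds than are shown below. What is called first, only, known or untested is meant among the compounds shown, and "the series" means these compounds.

Compound 1, `O=C(CCSc1nnc(-c2ccncc2)s1)Nc1ccc(Cl)cc1`, gives 8210 nM in an ADME assay on BHK-21 cells (Mesocricetus auratus) for cytotoxicity, with a stated time of 3 days; a lower number here means that less compound is tolerated, a higher number that more compound is tolerated.
Compound 2, `CC(Sc1nnc(-c2ccncc2)s1)C(=O)Nc1c(Cl)cccc1Cl`, is recorded in this assay only as a limit, > 50000 nM.

Going by the values given here, compound 1 therefore holds the only actual number in this assay; the other entry is a limit of the measurement rather than a value, as the evidence at the limit of > 50000 nM in this assay, at which 1 of the 2 values shown sits, shows. Among the compounds with values here, no step between two measured compounds is available here, so the account rests on compound 1 alone.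

Compound 3, `O=C(CCSc1nnc(-c2ccncc2)s1)NCc1ccccc1`, has not yet been measured in this assay. It differs from compound 1 in a single place: benzyl in place of 4-chlorophenyl on an amide-type nitrogen. The amide-type nitrogen keeps its carbonyl neighbour, and the shared core is untouched.

With only compound 1 as an anchor, the direction of the step is open. A move of this kind is expected to leave compound 3 near compound 1, perhaps somewhat more tolerated, with the step from compound 1 to compound 3 estimated at a 1.8-fold higher number from compound 1 to compound 3 (0.26 log units; within the scatter), close to the usual scatter. Compound 3 is accordingly estimated at 15000 nM in this assay, within a range from 5000 nM to 50000 nM.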

Compound 3, half-maximal cytotoxic concentration: 18700 nM
Beside the measured number, compound 3's estimate is 1.2-fold (0.10 log units) below it, within the range that was stated.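

In this assay, going by these compounds alone, the exchange on the amide-type nitrogen gives the first measured step at this place, a 2.3-fold higher number from compound 1 to compound 3 (0.36 log units; beyond the scatter), so this nitrogen's substituent can shift the tolerated concentration modestly, with the higher number going to the benzyl group. The change leaves the carbonyl neighbour and the shared core in place, and the two groups match in heavy-atom count and in having one six-membered aromatic ring of carbon only, so a step beyond the scatter arises even where these counted features stay equal. Nothing available gives a measured property that would account for this step.

The swap removes the chlorine and also places a carbon in the link from the nitrogen to the ring, and the compounds shown cannot tell which of these two differences carries the step. A plain phenyl or a 4-chlorobenzyl group on the same nitrogen would separate them, and a longer chain such as 2-phenylethyl would show whether the number keeps moving in the same direction.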